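Working notes: from compound 3 to compound 4

The compounds below may be only part of what the source reports. "The series", "measured", "known", "first", "only" and "open" are said of these compounds alone.

Measured in a functional assay on A549 cells (Homo sapiens) for inhibition, read by sulforhodamine B assay; a higher number here means a weaker inhibitor, a lower number a stronger inhibitor
compound 1 `COC(=O)CC/C(C)=C/Cc1c(OC)c(C)c2c(c1OCC#CCN1CCN(c3ccccc3F)CC1)C(=O)OC2` gives 45300 nM
compound 2 `COC(=O)CC/C(C)=C/Cc1c(OC)c(C)c2c(c1OCC#CCN1CCN(c3ccc(O)cc3)CC1)C(=O)OC2` gives > 50000 nM as a limit
compound 3 `COC(=O)CC/C(C)=C/Cc1c(OC)c(C)c2c(c1OCC#CCN1CCN(c3ccccc3OC)CC1)C(=O)OC2` gives > 50000 nM as a limit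

Compound 3 stands at the limit of > 50000 nM in this assay, at which 2 of the 3 values shown sit, with no number of its own. In compound 4 `COC(=O)CC/C(C)=C/Cc1c(OC)c(C)c2c(c1OCC#CCN1CCN(C(=O)C3COc4ccccc4O3)CC1)C(=O)OC2` the change is (2,3-dihydro-1,4-benzodioxin-2-yl)carbonyl in place of 2-methoxyphenyl on an amine nitrogen in a ring with (2,3-dihydro-1,4-benzodioxin-2-yl)carbonyl in place of 2-methoxyphenyl on an amine nitrogen in a ring. The measured steps of an at least 1.1-fold higher number from compound 1 to compound 2 (0.04 log units; that floor lies within the scatter) and an at least 1.1-fold higher number from compound 1 to compound 3 (0.04 log units; that floor lies within the scatter) stay within the scatter while a step that the two limits leave unreadable from compound 2 to compound 3 gives no readable size. None of them puts a carbonyl on that nitrogen. Resting on an at least 1.1-fold higher number from compound 1 to compound 3 (0.04 log units; that floor lies within the scatter) the expected change in this assay is a number no higher from compound 3 to compound 4 (the limit leaves the size open) with no step beyond the scatter in either direction. Compound 4 is estimated at 50000 nM with an expected range from 25000 nM to 100000 nM and a report as a limit is likely.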

Compound 4, half-maximal inhibitory concentration: > 50000 nM
Compound 4 ended at the assay's limit (the forecaster's own chance of this, stated with the estimate: 75%); the middle value sits exactly at the limit.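

With (2,3-dihydro-1,4-benzodioxin-2-yl)carbonyl on the amine nitrogen, compound 4 puts a carbonyl at this position, which compounds 1 to 3 lack, and this assay gives an at least 1.1-fold higher number from compound 1 to compound 4 (0.04 log units; that floor lies within the scatter). The steps to compound 4 from compound 2 and from compound 3 cannot be read, since both ends of each are limits. Swapping the aryl groups for this acyl group therefore yields no readable value, and the series gathers further at one limit: the limit of > 50000 nM in this assay, at which 3 of the 4 values shown sit.

How compound 2, compound 3 and compound 4 differ from one another stays hidden behind that limit. Also open, from the compounds shown here alone, is whether a benzyl group on that nitrogen, or a carboxylic acid in place of the methyl ester, would give a value under the limit.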